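A few compounds are considered here, and "the series" means these few. Any claim that something is new, unique, unknown or untested is made for them only; others in the source may bear on it.

Measured in a functional assay on A549 cells (Homo sapiens) for inhibition, read by MTT assay, with a stated time of 96 h; on this read-out lower numbers stand for stronger inhibition and higher numbers for weaker inhibition
- compound 1 `CC(=O)O[C@H](CN)CC(=O)O/N=C1C(=C2/C(=O)Nc3ccccc32)/Nc2ccc(O)cc2/1` gives 7600 nM
- compound 2 `NCCO/N=C1C(=C2/C(=O)Nc3ccccc32)/Nc2ccc(O)cc2/1` gives 13000 nM

Among the measured compounds shown here, compound 2 lies within the scatter of compound 1, the only other measured compound. Compound 3 `NCCO/N=C1C(=C2/C(=O)Nc3ccc(Br)cc32)/Nc2ccc(O)cc2/1` differs from compound 2 by bromo in place of hydrogen on an aromatic carbon. For the measured compounds named here, the one measured step, a 1.7-fold higher number from compound 1 to compound 2 (0.23 log units; within the scatter), changes the group on an oxygen and says nothing direct about bromo in place of hydrogen on an aromatic carbon. From the compounds shown here alone, no step beyond the scatter is therefore expected in this assay, and the direction stays open. The estimated step is a 1.6-fold lower number from compound 2 to compound 3 (0.21 log units; within the scatter). For compound 3 the expected value is 8000 nM, with an estimated range of 2000 nM to 20000 nM.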

Compound 3, half-maximal inhibitory concentration: 1000 nM
The estimate for compound 3 lay 8.0-fold (0.90 log units) above the measured number; measured number outside the range, below it.
By their numbers in this assay, from the lowest: compound 3; then compounds 1 and 2 (each within the scatter of the next).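

In this assay, among the compounds shown here, bromo in place of hydrogen on an aromatic carbon gives a 13-fold lower number from compound 2 to compound 3 (1.11 log units; beyond the scatter), the first step beyond the scatter. The earlier change, on an oxygen, stayed within the scatter, so this aromatic carbon, meta to a fused ring and para to a fused ring, is the first position shown to respond to a single substitution. Nothing available explains this step.

Whether the step is specific to bromo stays open, as chloro, methyl or methoxy at this carbon is not among the compounds shown. Also open, from the compounds shown here alone, is whether bromo gives a similar step with the group on oxygen of compound 1.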